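The compounds below may be only part of what the source reports. "The series", "measured", "known", "first", "only" and "open" are said of these compounds alone.

In a functional assay on Jurkat cells (Homo sapiens) for antiproliferative activity, read by MTT assay, with a stated time of 72 h (a lower number here means a stronger inhibitor, a higher number a weaker inhibitor), compound 1 `COc1cc(-n2ncnc2-c2ccc(Cl)c(Cl)c2)cc(OC)c1OC` gives > 10000 nM, which is a limit and not a number. Compound 2 `COc1cc(-n2ncnc2-c2cccc(F)c2)cc(OC)c1OC` gives > 10000 nM, which is also a limit. The evidence so far is therefore a single level: the limit of > 10000 nM in this assay, at which 2 of the 2 values shown sit. Among the compounds with values here, the only measured change is a step that the two limits leave unreadable from compound 1 to compound 2, so no size can be carried forward from it. Compound 3 `COc1cc(-n2ncnc2-c2ccc(SC)cc2)cc(OC)c1OC` brings a new change: 4-(methylsulfanyl)phenyl in place of 3-fluorophenyl on an aromatic carbon. This swap is 4-(methylsulfanyl)phenyl in place of 3-fluorophenyl, on an aromatic carbon of a five-membered aromatic ring with 3 nitrogen. Within the data shown here, no measured step predicts its size, so only a cautious move towards stronger inhibition in this assay is expected, and another limit is quite possible. The estimated change is an at least 2.5-fold lower number from compound 2 to compound 3 (0.39 log units; beyond the scatter). For compound 3 the expected value is 4000 nM, with an estimated range of 200 nM to 10000 nM.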

Compound 3, half-maximal inhibitory concentration: 50 nM
Estimate against measurement, compound 3: 80-fold (1.90 log units) above, outside the stated range (below it).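

On this aromatic carbon of the five-membered ring, the aryl group makes a large difference in this assay: 4-(methylsulfanyl)phenyl in place of 3-fluorophenyl gives an at least 200-fold lower number from compound 2 to compound 3 (2.30 log units; beyond the scatter), and in place of 3,4-dichlorophenyl it gives an at least 200-fold lower number from compound 1 to compound 3 (2.30 log units; beyond the scatter). With the shared core unchanged, this shows that compounds of this series can reach a measurable level of activity, and both steps are minimum sizes. Compound 1 and compound 2 remain limits and not numbers, so the true size of each step stays hidden: the limit of > 10000 nM in this assay, at which 2 of the 3 values shown sit.

Compound 3 differs from the other two both in the atoms on its phenyl ring and in where they sit, so the compounds shown do not separate the sulfur from its location. From the compounds shown here alone, how a 4-methoxyphenyl group, with oxygen instead of sulfur, or a longer 4-(ethylsulfanyl)phenyl group would behave in this assay stays open.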